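This account rests on a few compounds, and the source may have more. Where it says the series, first, only, none or still open, it means among the compounds named here.

In a functional assay on HeLa cells (Homo sapiens) for cytotoxicity, read by LDH release, with a stated time of 48 h (a higher number here means a weaker inhibitor, a lower number a stronger inhibitor), compound 2 (`Cn1cnc(C(=O)NNC(=O)COc2c(F)cc(C(=O)c3ccc(F)cc3)cc2Cl)c1`) gives 40900 nM. Compound 1 (`O=C(COc1c(F)cc(C(=O)c2ccc(F)cc2)cc1Cl)NNC(=O)c1ccc(=O)oc1`) gives 60100 nM, which is level with compound 2 once the usual scatter is allowed for. Compound 3 (`O=C(COc1ccc(C(=O)c2ccccc2)cc1)NNC(=O)c1ccc(=O)oc1`) gives 96100 nM, a higher number than that of compound 2 and one beyond the scatter.

The next compound to be measured is compound 4 (`Cc1ccc(C(=O)c2cc(F)c(OCC(=O)NNC(=O)c3cn(C)cn3)c(Cl)c2)cc1`). It turns the 4-fluorophenyl of compound 2 into 4-methylphenyl, with methyl in place of fluoro on an aromatic carbon.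

Among the measured compounds shown here, the only measured step between compounds that differ in one place is a 1.5-fold lower number from compound 1 to compound 2 (0.17 log units; within the scatter). That step swaps a different group, so no measurement here isolates the exchange of fluoro for methyl. It offers only a weak hint that a single change can leave this number little moved.

The expected size is therefore no step beyond the scatter, and no direction can be favoured: a 1.0-fold higher number from compound 2 to compound 4 (0.01 log units; within the scatter). For compound 4 the estimated value is 42000 nM, with an expected range of 20000 nM to 90000 nM.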

Compound 4, half-maximal inhibitory concentration: 10400 nM
Compound 4: the middle estimate sits 4.0-fold (0.61 log units) above what was measured; measured number below the stated range.
By their numbers in this assay, from the lowest: compound 4; then compounds 2, 1 and 3 (each within the scatter of the next, the first and the last beyond it).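

In this assay, turning 4-fluorophenyl into 4-methylphenyl gives a 3.9-fold lower number from compound 2 to compound 4 (0.59 log units; beyond the scatter) and so shows that the number responds to what sits at this place on the aromatic ring. Among the compounds shown here, the only earlier step between compounds differing in one place, a change of a different group on the carbonyl carbon, stayed within the scatter, so this exchange of fluoro for methyl is the first single change here to move the number beyond it. Nothing available here explains why the number moved with this exchange.

Going by these compounds, whether other groups at this place, such as chloro, methoxy, ethyl or an amine, would lower the number further or raise it remains open. On these data alone, it is also open whether the same exchange would have a similar effect on the core of compound 1.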